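The source may report more compounds than this note shows. Statements on the series, on what has been measured and on what is new or still open speak of the compounds shown alone.

Series notes, shared core as shown in compound 1 `NS(=O)(=O)OC[C@@H]1C[C@@H](n2nnc3c(N[C@H]4CCc5ccccc54)ncnc32)C[C@@H]1O`. In an assay on a protein complex for inhibition of NEDD8 activating enzyme (Homo sapiens), read by HTRF, with a stated time of 2 h, in the presence of a further agent that is not named here (on this read-out lower numbers stand for stronger inhibition and higher numbers for weaker inhibition), compound 1 gives 0.21 nM, the lowest number of the three measured. The nearest is compound 2 `NS(=O)(=O)OC[C@@H]1C[C@@H](n2nnc3c(NCc4cccs4)ncnc32)C[C@@H]1O`, which in this assay gives 15.9 nM, and the furthest is compound 3 `NS(=O)(=O)OC[C@@H]1C[C@@H](n2nnc3c(NCCCc4ccccc4)ncnc32)C[C@@H]1O`, which in this assay gives 149 nM. Both measured steps away from compound 1 are losses: a 76-fold higher number from compound 1 to compound 2 (1.88 log units; beyond the scatter) and a 710-fold higher number from compound 1 to compound 3 (2.85 log units; beyond the scatter). Between the two weaker compounds, a 9.4-fold higher number from compound 2 to compound 3 (0.97 log units; beyond the scatter).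

Compound 4 `NS(=O)(=O)OC[C@@H]1C[C@@H](n2nnc3c(Nc4cnc5ccccn45)ncnc32)C[C@@H]1O` is not yet measured. Relative to compound 1 the change is a group of 9 heavy atoms (7 carbon, 2 nitrogen; one five-membered aromatic ring with 2 hetero atoms, one six-membered aromatic ring with 1 hetero atom) in place of a group of 9 heavy atoms (9 carbon; one five-membered non-aromatic ring of carbon only, one six-membered aromatic ring of carbon only), on a nitrogen on an aromatic ring. Neither measured step copies this change: in compound 2 and compound 3 the replacing groups reach the nitrogen through a saturated chain carbon, whereas in compound 4 the entering group, built from two aromatic rings, is bound to the nitrogen with no chain. What the two measured steps do show is that each replacement of 2,3-dihydro-1H-inden-1-yl tried so far raised the number considerably, so a rise is expected here as well, most likely within the span of the two measured losses rather than none at all. Compound 4 is therefore estimated at 15 nM in this assay, with a range of 1.5 nM to 150 nM, which corresponds to an expected 71-fold higher number from compound 1 to compound 4 (1.85 log units; beyond the scatter).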

Compound 4, half-maximal inhibitory concentration: > 10000 nM
Compound 4 was reported as a limit (the forecaster's own chance of this, stated with the estimate: 5%); middle value at least 660-fold (2.82 log units) from the limit.
By their numbers in this assay, from the lowest: compound 1; then compound 2; then compound 3. At a limit, above all of these: compound 4.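

In this assay compound 4 stands at a limit, not at a number: the limit of > 10000 nM in this assay, at which 1 of the 4 values shown sits.

Even so, the steps to it are the largest in the series: an at least 47000-fold higher number from compound 1 to compound 4 (4.67 log units; beyond the scatter), an at least 620-fold higher number from compound 2 to compound 4 (2.79 log units; beyond the scatter) and an at least 67-fold higher number from compound 3 to compound 4 (1.82 log units; beyond the scatter). The entering group has the same count of 9 heavy atoms as 2,3-dihydro-1H-inden-1-yl, so at this position, on a nitrogen on an aromatic ring, an equal heavy-atom count and two rings do not by themselves hold the number near that of compound 1.

Compound 4 changes several things at once, since its group is bound to the nitrogen with no chain, is fully aromatic, and carries 2 nitrogen atoms and 2 hydrogen-bond acceptors, and the compounds shown do not separate these features. A plain phenyl on the nitrogen would test the missing chain without the ring nitrogens, while a benzyl group or the same two-ring group reached through a single methylene carbon would test the chain itself.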